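Trifluoromethyl in Place of Chloro: Estimating Compound 4

This account rests on a few compounds, and the source may have more. Where it says the series, first, only, none or still open, it means among the compounds named here.

Three measured compounds share one core and differ only in a single group on one aromatic ring. Compound 1 `Cc1ccc(O)c(C(=O)Nc2ccc(C#N)cc2)c1` carries a methyl there, and in a functional assay on KG-1 cells (Homo sapiens) for cytotoxicity, read by luminescence and CellTiter-Glo, with a stated time of 3 days (a higher number here means a weaker inhibitor, a lower number a stronger inhibitor), compound 1 gives 3370 nM. Compound 2 `N#Cc1ccc(NC(=O)c2cc(F)ccc2O)cc1` carries a fluoro, and in this assay compound 2 gives 2670 nM. Compound 3 `N#Cc1ccc(NC(=O)c2cc(Cl)ccc2O)cc1` carries a chloro, and in this assay compound 3 gives 1860 nM. Compound 3 has the lowest of the three numbers, but every step to it stays within the scatter: a 1.8-fold lower number from compound 1 to compound 3 (0.26 log units; within the scatter) and a 1.4-fold lower number from compound 2 to compound 3 (0.16 log units; within the scatter). The remaining step, a 1.3-fold lower number from compound 1 to compound 2 (0.10 log units; within the scatter), is also within the scatter, so the three measured compounds cannot be ranked against each other.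

Compound 4 `N#Cc1ccc(NC(=O)c2cc(C(F)(F)F)ccc2O)cc1` is the next variation at the same place: trifluoromethyl in place of chloro on an aromatic carbon. All three measured steps exchange one small group for another at this position, and none moves the number beyond the scatter. A fourth exchange of the same kind is therefore expected to behave alike, and the step of a 1.1-fold lower number from compound 3 to compound 4 (0.04 log units; within the scatter) is estimated to lie within the scatter. Compound 4 is expected to give about 1700 nM in this assay, with a likely range from 700 nM to 4200 nM.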

Compound 4, half-maximal inhibitory concentration: 4810 nM
Beside the measured number, compound 4's estimate is 2.8-fold (0.45 log units) below it, and the stated range ends below it.
By their numbers in this assay, from the lowest: compounds 3, 2, 1 and 4 (each within the scatter of the next, the first and the last beyond it).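

Trifluoromethyl gives the first step at this position in this assay that lies beyond the scatter (a 2.6-fold higher number from compound 3 to compound 4 (0.41 log units; beyond the scatter)), so exchanges among small groups here are not all equally quiet, although the step is labelled modest. The change stands out only against chloro: the other two new steps stay within the scatter (a 1.8-fold higher number from compound 2 to compound 4 (0.26 log units; within the scatter); a 1.4-fold higher number from compound 1 to compound 4 (0.15 log units; within the scatter)), so compound 4 cannot be separated from compound 1 or compound 2, and the only firm contrast in the series is between compound 3 and compound 4. Nothing measured here explains this contrast, even though the change replaces one heavy atom with four.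

The compounds shown leave open how this position responds to quite different groups, such as an amine, a carboxylic acid or a longer chain, and whether any of them would move the number beyond the scatter relative to compound 3 in either direction. They also leave open whether the contrast between chloro and trifluoromethyl would persist if the nitrile or the hydroxy group of the shared core were replaced.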